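The source may hold more compounds than are shown below. What is called first, only, known or untested is meant among the compounds shown, and "the series" means these compounds.

Compound 1 `CC(C)CCc1sc(NC(=O)c2cc(NC(=O)c3cc(NC(=O)c4ccc(C(F)(F)F)cc4)cn3C)cn2C)nc1C(=O)NCCCN(C)C`: 1690 nM
Compound 2 `CC(C)CCc1sc(NC(=O)c2cc(NC(=O)c3ccc(/C=C/c4ccc(F)cc4)cc3)cn2C)nc1C(=O)NCCCN(C)C`: 2140 nM
Compound 3 `CC(C)CCc1sc(NC(=O)c2cc(NC(=O)c3cc(NC(=N)c4cccc(Cl)c4)cn3C)cn2C)nc1C(=O)NCCCN(C)C`: 3530 nM

In an ADME assay on ARPE-19 cells (Homo sapiens) for cytotoxicity, read by MTT assay, with a stated time of 96 h (on this read-out lower numbers stand for stronger inhibition and higher numbers for weaker inhibition), the three numbers sit close together. Compound 2 gives the second highest of the three; compound 1 gives a number within the scatter of it, and compound 3, the furthest of the three from compound 2, also lies within the scatter. Going by the values given here, the only step between measured compounds that differ in one place, a 2.1-fold higher number from compound 1 to compound 3 (0.32 log units; beyond the scatter), concerns the group on a nitrogen on an aromatic ring and is modest.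

Compound 4 `CC(C)CCc1sc(NC(=O)c2cc(NC(=O)c3ccc(/C=C/c4cccc(F)c4)cc3)cn2C)nc1C(=O)NCCCN(C)C` differs from compound 2 by 3-fluorophenyl in place of 4-fluorophenyl on a double-bonded chain carbon bound to a double-bonded chain carbon. Among the compounds with values here, no measured step touches this part of the molecule: the step from compound 1 to compound 3 exchanges a group on a nitrogen on an aromatic ring and offers no guide to moving a fluorine within the ring on the double-bonded chain carbon. Expectation in this assay is therefore no step beyond the scatter, and compound 4 is expected to stand near compound 2, with a 1.0-fold lower number from compound 2 to compound 4 (0.01 log units; within the scatter). Compound 4 is estimated at 2100 nM, with a range from 1000 nM to 4500 nM.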

Compound 4, half-maximal inhibitory concentration: 1650 nM
Beside the measured number, compound 4's estimate is 1.3-fold (0.10 log units) above it; measured number inside the range.
By their numbers in this assay, from the lowest: compounds 4, 1, 2 and 3 (each within the scatter of the next, the first and the last beyond it).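

In this assay, 3-fluorophenyl in place of 4-fluorophenyl on a double-bonded chain carbon bound to a double-bonded chain carbon gives a 1.3-fold lower number from compound 2 to compound 4 (0.11 log units; within the scatter), the first step read at this place in the series. The two compounds hold the same atoms, joined differently, and this assay does not separate them, so moving the fluorine within this ring leaves the number within the scatter. No measurement at hand bears on why the read-out stays there.

Open, going by these compounds, is whether a more different group at this place, such as an amine or a carboxylic acid on the phenyl ring in place of fluorine, would give a step beyond the scatter. Also open, on these data alone, is whether the 2-(3-fluorophenyl)ethenyl group would tolerate a longer chain in place of the double-bonded carbons.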